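Swapping the outer phenyl for trifluoromethyl on the cytotoxicity series

The source may report more compounds than this note shows. Statements on the series, on what has been measured and on what is new or still open speak of the compounds shown alone.

Of the compounds shown here, three sharing one core have been tested in an ADME assay on MT4 cells (Homo sapiens) for cytotoxicity, read by MTT assay, with a stated time of 5 days; a higher number here means that more compound is tolerated, a lower number that less compound is tolerated. Compound 1 `Cc1cc(C)cc(-c2cnc(Nc3ccc(C#N)cc3)nc2Oc2c(C)cc(C#N)cc2C)c1` gives 39000 nM in this assay. Compound 2 `Cc1cc(C#N)cc(C)c1Oc1nc(Nc2ccc(C#N)cc2)ncc1-c1ccsc1` gives 3920 nM in this assay. For compound 3 `Cc1cc(C#N)cc(C)c1Oc1nc(Nc2ccc(C#N)cc2)ncc1-c1ccc(-c2ccccc2)cc1` this assay reports only a limit, > 253000 nM, so no exact number is known for it. The change from compound 1 to compound 2 was a 9.9-fold lower number from compound 1 to compound 2 (1.00 log units; beyond the scatter); the change from compound 1 to compound 3 was an at least 6.4-fold higher number from compound 1 to compound 3 (0.81 log units; beyond the scatter); and the change from compound 2 to compound 3 was an at least 64-fold higher number from compound 2 to compound 3 (1.80 log units; beyond the scatter). Compound 4 `Cc1cc(C#N)cc(C)c1Oc1nc(Nc2ccc(C#N)cc2)ncc1-c1ccc(C(F)(F)F)cc1` differs from compound 3 by trifluoromethyl in place of phenyl on an aromatic carbon. The measured steps show that the group at this position moves the number strongly, and that the 4-phenylphenyl group of compound 3 sits at the limit (the limit of > 253000 nM in this assay, at which 1 of the 3 values shown sits). Replacing it with a smaller group is expected to bring the number back down, towards the range of compound 1, so for compound 4 a step of an at least 4.2-fold lower number from compound 3 to compound 4 (0.62 log units; beyond the scatter) is estimated. Compound 4 is therefore expected to give about 60000 nM, within 15000 nM to 253000 nM.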

Compound 4, half-maximal cytotoxic concentration: 35000 nM
Estimate against measurement, compound 4: 1.7-fold (0.23 log units) above; low and high end bracket the measured number.
By their numbers in this assay, from the lowest: compound 2; then compounds 4 and 1 (each within the scatter of the next). At a limit, above all of these: compound 3.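

In this assay, trifluoromethyl in place of the outer phenyl gives an at least 7.2-fold lower number from compound 3 to compound 4 (0.85 log units; beyond the scatter), so the result for 4-phenylphenyl does not extend to every group on this aromatic carbon. The 4-(trifluoromethyl)phenyl and 3,5-dimethylphenyl groups cannot be told apart here, with a 1.1-fold lower number from compound 1 to compound 4 (0.05 log units; within the scatter), so two quite different substituted phenyl rings can give matching numbers at this position. Set against thiophen-3-yl, 4-(trifluoromethyl)phenyl gives an 8.9-fold higher number from compound 2 to compound 4 (0.95 log units; beyond the scatter), which shows that the thiophene-bearing compound stands apart from both phenyl-bearing compounds with exact numbers.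

As far as these compounds go, compound 3 remains a limit and not a number, so the true size of its step stays open: the limit of > 253000 nM in this assay, at which 1 of the 4 values shown sits. Also open is how an unsubstituted phenyl ring, or a phenyl ring carrying an amine or a carboxylic acid, would compare at this position.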